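A Chloro-for-Fluoro Swap at a Growth Assay Limit

A few compounds are considered here, and "the series" means these few. Any claim that something is new, unique, unknown or untested is made for them only; others in the source may bear on it.

In a functional assay on U-251 cells (Homo sapiens) for inhibition, read by sulforhodamine B assay, with a stated time of 48 h (a lower number here means a stronger inhibitor of growth, a higher number a weaker inhibitor of growth), compound 1 `CC(C)(C)NCc1c(C(=O)O)nn(-c2ccccc2)c1-c1ccc(Cl)cc1` gives > 652000 nM, which is a limit of the assay and not a number. Compound 2 `CC(C)(C)NCc1c(C(=O)O)nn(-c2ccc(Cl)cc2)c1-c1ccc(F)cc1` gives > 623000 nM, and this too is a limit. Among the compounds with values here, compound 2 therefore has no exact place on the scale, and the only other measured value offers no exact comparison. Compound 3 `CC(C)(C)NCc1c(C(=O)O)nn(-c2ccc(Cl)cc2)c1-c1ccc(Cl)cc1` keeps the shared core of compound 2 and changes one group, from 4-fluorophenyl to 4-chlorophenyl. This places chloro in place of fluoro on an aromatic carbon, para to a large group: chloro in place of fluoro on an aromatic carbon. Within the data shown here, no measured pair shows this change on its own, so no shift beyond the usual scatter is expected in this assay. The estimated change is an at least 1.0-fold lower number from compound 2 to compound 3 (0.01 log units; that floor lies within the scatter), and the result may again be only a limit. For compound 3, the expected value is 600000 nM, with an estimated range of 300000 nM to 1000000 nM.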

Compound 3, concentration for 50% growth inhibition: 518000 nM
For compound 3 the middle estimate is 1.2-fold (0.06 log units) above the measured one; the measured number falls inside the stated range.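

In this assay, compound 3 is the only one of the three compounds shown with an exact number rather than a limit, so the 4-chlorophenyl group gives this position its first real reading. Chloro in place of fluoro gives an at least 1.2-fold lower number from compound 2 to compound 3 (0.08 log units; that floor lies within the scatter), and swapping a hydrogen for chloro gives an at least 1.2-fold lower number from compound 1 to compound 3 (0.09 log units; that floor lies within the scatter). That floor is all the fluoro-to-chloro swap can show, because compound 2 has no exact value: the limit of > 623000 nM in this assay, at which 1 of the 3 values shown sits.

On these data alone, whether a bromo or methoxy group in the same place, or an amide in place of the carboxylic acid, would give a clearly lower number stays open. As far as these compounds go, how far compound 1 and compound 2 truly lie from compound 3 also stays open while those two remain limits.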